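Amino to propoxy on a shared core

The source may report more compounds than this note shows. Statements on the series, on what has been measured and on what is new or still open speak of the compounds shown alone.

Compound 1 `CCCCN(CC)c1nc(C)nc2c1nnn2-c1ccc(C(C)C)cc1Br` gives 49.2 nM as its value
Compound 2 `CCC(COC)Nc1nc(C)nc2c1nnn2-c1ccc(C(C)C)cc1Br` gives 30.7 nM as its value

Both numbers come from an in vivo ADME assay on the whole organism (plasma) with Rattus norvegicus as the target, at a dose of 1 mg/kg by the oral route (on this read-out lower numbers stand for lower exposure and higher numbers for higher exposure at the dose given), and compound 2 stands within the scatter of compound 1.

Compound 3 `CCC(COC)Oc1nc(C)nc2c1nnn2-c1ccc(C(C)C)cc1Br` alters one group of compound 2 (1-(methoxymethyl)propoxy in place of (1-(methoxymethyl)propyl)amino on an aromatic carbon), on an aromatic carbon of the shared core. Among the measured compounds shown here, only one measured step touches this same place, a 1.6-fold lower number from compound 1 to compound 2 (0.20 log units; within the scatter), and no measured step puts an oxygen-linked group there. In this assay no shift beyond the scatter is therefore expected. The expected change is a 1.2-fold higher number from compound 2 to compound 3 (0.09 log units; within the scatter) for now. Compound 3 is estimated at 38 nM, within an expected range of 12 nM to 120 nM on this read-out.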

Compound 3, maximal plasma concentration: 5.9 nM
Compound 3: the middle estimate sits 6.4-fold (0.81 log units) above what was measured; measured number below the stated range.
By their numbers in this assay, from the lowest: compound 3; then compounds 2 and 1 (each within the scatter of the next).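

In this assay, the atom linking the side chain to this aromatic carbon matters more than compounds 1 and 2 could show: exchanging nitrogen for oxygen while keeping the same chain gives a 5.2-fold lower number from compound 2 to compound 3 (0.72 log units; beyond the scatter) at this position. The oxygen-linked group also stands apart from the butyl(ethyl)amino group, with an 8.3-fold lower number from compound 1 to compound 3 (0.92 log units; beyond the scatter) across that change. No measurement shown gives a reason for this drop.

As far as these compounds go, whether a sulfur link would behave like the oxygen link remains open. So does whether a shorter oxygen-linked chain, such as ethoxy, would give a similar number.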